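A few compounds are considered here, and "the series" means these few. Any claim that something is new, unique, unknown or untested is made for them only; others in the source may bear on it.

For the measured compounds named here, compound 2 `COc1ccc(F)cc1CNCCCNc1ccnc2cc(Cc3ccc(F)cc3Cl)ccc12` is one of three compounds measured in a physicochemical assay for solubility, with a stated time of 18 h, at pH 7.4; on this read-out higher numbers stand for higher solubility and lower numbers for lower solubility; in this assay compound 2 gives 4200 nM. Compound 3 `Fc1ccc(Cc2ccc3c(NCCCNCc4ccco4)ccnc3c2)c(Cl)c1` gives 4200 nM, level with compound 2, and together they stand lowest, while compound 1 `COc1cccc(CNCCCNc2ccnc3cc(-c4ccc(C(C)(C)C)cc4)ccc23)c1O` gives the highest number at 32000 nM. Going by the values given here, the single measured step, no change at the digits printed from compound 2 to compound 3 (within the scatter), concerns the group on the saturated chain carbon bound to the amine nitrogen, not the position changed here. Compound 4 `COc1ccc(-c2ccc3c(NCCCNCc4cc(F)ccc4OC)ccnc3c2)cc1` differs from compound 2 as follows: 4-methoxyphenyl in place of 2-chloro-4-fluorobenzyl on an aromatic carbon. Only compound 1, which also carries an aryl group at that place and shows the higher number, bears on this change. A rise in this assay is therefore expected, a 3.3-fold higher number from compound 2 to compound 4 (0.52 log units; beyond the scatter), and compound 4 is estimated at 14000 nM, in a range from 4000 nM to 50000 nM.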

Compound 4, solubility: 32000 nM
Compound 4: the middle estimate sits 2.3-fold (0.36 log units) below what was measured; the measured number falls inside the stated range.
By their numbers in this assay, from the lowest: compounds 2 and 3 (each within the scatter of the next); then compounds 1 and 4 (each within the scatter of the next).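

In this assay, replacing 2-chloro-4-fluorobenzyl with 4-methoxyphenyl on this aromatic carbon gives a 7.6-fold higher number from compound 2 to compound 4 (0.88 log units; beyond the scatter). For the compounds shown here, this is the first direct reading at this place, with the rest of the molecule unchanged, and it shows that the number here responds to the group on this carbon. No measurement shown explains the rise.

Going by these compounds alone, the single swap changes the benzyl link, the chlorine and fluorine, and the methoxy group together, so which of these matters stays open. So does how a plain phenyl group or an amine would read at this place.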